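This account rests on a few compounds, and the source may have more. Where it says the series, first, only, none or still open, it means among the compounds named here.

Going by the values given here, in a functional assay on HepG2 cells (Homo sapiens) for antiproliferative activity, read by MTT assay, with a stated time of 72 h (a higher number here means a weaker inhibitor, a lower number a stronger inhibitor), compound 1 (`COc1cc2c(Nc3cccc(C#N)c3)ncnc2cc1OCCCN1CCN(C)CC1`) gives 18300 nM and compound 2 (`CCN1CCN(CCCOc2cc3ncnc(Nc4cccc(C#N)c4)c3cc2OC)CC1`) gives 13700 nM, so compound 1 stands level with the only other measured compound, within the scatter. Compound 3 (`COc1cc2c(Nc3ccccc3C#N)ncnc2cc1OCCCN1CCN(C)CC1`) keeps the core of compound 1 but carries 2-cyanophenyl in place of 3-cyanophenyl on a nitrogen on an aromatic ring. Among the compounds with values here, only one measured step is available, a 1.3-fold lower number from compound 1 to compound 2 (0.13 log units; within the scatter), and it concerns a saturated chain carbon bound to an amine nitrogen in a ring, not the cyanophenyl group. It therefore bears on this change only indirectly, and the data hold no measured shift of the nitrile. With no evidence for a direction, a 1.0-fold higher number from compound 1 to compound 3 (0.02 log units; within the scatter) is expected in this assay, which is no step beyond the scatter. For compound 3 the estimated value is 19000 nM, with an expected range of 7000 nM to 50000 nM.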

Compound 3, half-maximal inhibitory concentration: 26400 nM
For compound 3 the middle estimate is 1.4-fold (0.14 log units) below the measured one; the measured number falls inside the stated range.
By their numbers in this assay, from the lowest: compounds 2, 1 and 3 (each within the scatter of the next).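

Swapping 3-cyanophenyl for 2-cyanophenyl on a nitrogen on an aromatic ring gives a 1.4-fold higher number from compound 1 to compound 3 (0.16 log units; within the scatter) in this assay, the first measured shift of the nitrile in this series. On this evidence, the two placements of the nitrile cannot be told apart in this assay, so the change neither clearly helps nor clearly harms antiproliferative activity at this position. Nothing at hand gives a reason for this result.

From the compounds shown here alone, whether the position tolerates other changes remains open, as an amide, a carboxylic acid or a chlorine in place of the nitrile would test more than the nitrile's placement. Going by these compounds, it is also open whether a hydroxyl or an amine on the phenyl ring could bring the number beyond the scatter of compound 1.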